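Ortho substituent on the pendant phenyl of the triazole amide

A few compounds are considered here, and "the series" means these few. Any claim that something is new, unique, unknown or untested is made for them only; others in the source may bear on it.

Among the measured compounds shown here, compound 3 `COc1cc2c(Oc3ccc(NC(=O)c4nnn(-c5ccccc5)c4C)cc3F)ccnc2cc1OCCCN1CCCCC1` gives 220 nM in a functional assay on NCI-H460 cells (Homo sapiens) for cytotoxicity, read by MTT assay, with a stated time of 72 h (on this read-out higher numbers stand for weaker inhibition and lower numbers for stronger inhibition), the lowest of the three numbers so far. Compound 1 `COc1cc2c(Oc3ccc(NC(=O)c4nnn(-c5ccccc5C(F)(F)F)c4C)cc3F)ccnc2cc1OCCCN1CCCC1` gives 230 nM in this assay, within the scatter of compound 3; compound 2 `COc1cc2c(Oc3ccc(NC(=O)c4nnn(-c5ccccc5C)c4C)cc3F)ccnc2cc1OCCCN1CCCCC1` gives 780 nM. Compound 4 `COc1cc2c(Oc3ccc(NC(=O)c4nnn(-c5ccccc5C(F)(F)F)c4C)cc3F)ccnc2cc1OCCCN1CCCCC1` differs from compound 3 by trifluoromethyl in place of hydrogen on an aromatic carbon, on an aromatic carbon of a six-membered aromatic ring of carbon only, ortho to a large group. For the measured compounds named here, the one bearing step is a 3.5-fold lower number from compound 2 to compound 3 (0.55 log units; beyond the scatter), so placing a group at this carbon has raised the number once. Compound 1 carries the same trifluoromethyl with a different amine and stands level with compound 3, which tempers that. A modest rise is expected for compound 4, a 1.6-fold higher number from compound 3 to compound 4 (0.20 log units; within the scatter). Compound 4 is estimated at 350 nM, range 150 nM to 900 nM.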

Compound 4, half-maximal inhibitory concentration: 280 nM
The estimate for compound 4 lay 1.3-fold (0.10 log units) above the measured number; low and high end bracket the measured number.
By their numbers in this assay, from the lowest: compounds 3, 1 and 4 (each within the scatter of the next); then compound 2.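

In this assay, trifluoromethyl and hydrogen on this aromatic carbon cannot be told apart (a 1.3-fold higher number from compound 3 to compound 4 (0.10 log units; within the scatter)), while methyl at the same carbon stands apart from trifluoromethyl (a 2.8-fold lower number from compound 2 to compound 4 (0.44 log units; beyond the scatter)), so the higher number of compound 2 does not extend to every group placed there. With trifluoromethyl in place, piperidin-1-yl and pyrrolidin-1-yl also cannot be told apart (a 1.2-fold higher number from compound 1 to compound 4 (0.09 log units; within the scatter)). No measurement at hand explains why methyl stands apart from trifluoromethyl. Open, going by these compounds, is whether chlorine or methoxy at this carbon would follow methyl or trifluoromethyl. Also open, on these data alone, is how morpholine would compare with either amine.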